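A few compounds are considered here, and "the series" means these few. Any claim that something is new, unique, unknown or untested is made for them only; others in the source may bear on it.

Measured compounds in a functional assay on MCF7 cells (Homo sapiens) for antiproliferative activity, read by MTT assay, with a stated time of 48 h; on this read-out lower numbers stand for stronger inhibition and higher numbers for weaker inhibition:

Compound 1 `Cc1ccc(-c2nc(NN)c3cc(Cl)ccc3n2)cc1`: 3.76 ug/mL
Compound 2 `Cc1ccc(-c2nc(NOC(=O)c3ccccc3)c3cc(Cl)ccc3n2)cc1`: 5.59 ug/mL
Compound 3 `Cc1ccc(-c2nc3ccc(Cl)cc3c(=O)n2N)cc1`: 5.39 ug/mL

The three numbers lie close together; the gaps from compound 1 to compound 2 and from compound 1 to compound 3 both fall inside the usual scatter, so no ranking among them is supported. Compound 4 `Cc1ccc(-c2nc(SCc3ccccc3)c3cc(Cl)ccc3n2)cc1` is not yet measured. It differs from compound 1 in one place: benzylsulfanyl in place of aminoamino on an aromatic carbon.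

For the measured compounds named here, no measured step exchanges this group for a benzylsulfanyl. Going by the values given here, the only single-point step on the shared core is a 1.5-fold higher number from compound 1 to compound 2 (0.17 log units; within the scatter), which also replaces part of the aminoamino group by a larger fragment carrying a six-membered aromatic ring of carbon only, and the read-out hardly moved. Compound 3, which carries a different arrangement at the same region, gives a number in the same band. On this basis the expected step of a 1.5-fold higher number from compound 1 to compound 4 (0.17 log units; within the scatter) is small, with no direction beyond the scatter claimed. The estimate for compound 4 in this assay is 5.5 ug/mL, with a range from 2.5 ug/mL to 12 ug/mL.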

Compound 4, half-maximal inhibitory concentration: 9.66 ug/mL
For compound 4 the middle estimate is 1.8-fold (0.24 log units) below the measured one; measured number inside the range.
By their numbers in this assay, from the lowest: compounds 1, 3, 2 and 4 (each within the scatter of the next, the first and the last beyond it).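

In this assay the aromatic carbon next to the ring nitrogen now shows a step beyond the scatter, with benzylsulfanyl in place of aminoamino: a 2.6-fold higher number from compound 1 to compound 4 (0.41 log units; beyond the scatter). For the compounds shown here, the earlier compounds gave only differences within the scatter, so this is the first sign that the read-out responds to the group here, although the step is modest and runs towards weaker inhibition. The change removes 2 hydrogen-bond donors and brings in sulfur and a six-membered aromatic ring of carbon only, and no available evidence bears on the cause of the rise.

Which of these features goes with the rise remains open. A benzylamino or a methylsulfanyl group on the same carbon would separate the sulfur link from the added ring.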